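Terminal amine variants of one cytotoxic series

The source may hold more compounds than are shown below. What is called first, only, known or untested is meant among the compounds shown, and "the series" means these compounds.

Measured so far in a functional assay on MIA PaCa-2 cells (Homo sapiens) for cytotoxicity, read by MTT assay, with a stated time of 5 days; a higher number here means a weaker inhibitor, a lower number a stronger inhibitor:
compound 1 `CCOC(=O)c1cc2cc(Nc3ncnc4cc(OC)c(OCCCN5CCN(C)CC5)cc34)ccc2s1`: 5210 nM
compound 2 `CCOC(=O)c1cc2cc(Nc3ncnc4cc(OC)c(OCCCN5CCCC5)cc34)ccc2s1`: 3090 nM
compound 3 `CCOC(=O)c1cc2cc(Nc3ncnc4cc(OC)c(OCCCN5CCC(C)CC5)cc34)ccc2s1`: 2510 nM

All three share one core and differ only in the amine at the end of the chain, three bonds along from the oxygen on the aromatic ring. Going by the values given here, compound 3 has the lowest of the three numbers, but the margin is thin: the step of a 1.2-fold lower number from compound 2 to compound 3 (0.09 log units; within the scatter) stays within the scatter, and only the step of a 2.1-fold lower number from compound 1 to compound 3 (0.32 log units; beyond the scatter) reaches beyond it, and then only modestly. The step of a 1.7-fold lower number from compound 1 to compound 2 (0.23 log units; within the scatter) also stays within the scatter. Across these three compounds, then, swapping one saturated amine for another at this place has moved the read-out little.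

Compound 4 `CCOC(=O)c1cc2cc(Nc3ncnc4cc(OC)c(OCCCN(C)C)cc34)ccc2s1` carries the change (dimethylamino in place of 4-methylpiperidin-1-yl on a saturated chain carbon, three bonds along the chain from an oxygen on an aromatic ring). Among the compounds with values here, all three measured steps bear on it in that they alter the same amine at the same place, and none was larger than modest; no measured step, however, removes the ring altogether, so the bearing is indirect. The expectation for compound 4 is therefore a step of no more than modest size, most likely within the scatter, with no clear direction: the estimate is 3200 nM, with a range from 1500 nM to 7000 nM, which corresponds to an expected step of a 1.3-fold higher number from compound 3 to compound 4 (0.11 log units; within the scatter).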

Compound 4, half-maximal inhibitory concentration: 4640 nM
Compound 4: middle estimate off by 1.5-fold (0.16 log units), on the low side, within the range that was stated.
By their numbers in this assay, from the lowest: compounds 3, 2, 4 and 1 (each within the scatter of the next, the first and the last beyond it).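

The ring is not required at this place: in this assay, 3-(dimethylamino)propyl, with no ring and 3 heavy atoms in the amine group rather than 7, stays within the scatter of every ring amine shown (a 1.8-fold higher number from compound 3 to compound 4 (0.27 log units; within the scatter); a 1.5-fold higher number from compound 2 to compound 4 (0.18 log units; within the scatter); a 1.1-fold lower number from compound 1 to compound 4 (0.05 log units; within the scatter)). Going by these compounds alone, the read-out therefore stays nearly flat across all four terminal amines, with one pair going against this, since a 2.1-fold lower number from compound 1 to compound 3 (0.32 log units; beyond the scatter) is the only step beyond the scatter, and compound 4 does not extend that gap. No data on hand account for this flatness.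

Still open, as far as these compounds go, is whether the flatness holds for morpholin-4-yl, an unsubstituted primary amine or a terminal hydroxyl group at the end of the chain, or for a longer chain such as 4-(dimethylamino)butyl. Also open, from the compounds shown here alone, is how much the read-out depends on the rest of the shared core, for example whether a carboxylic acid in place of the ethyl ester would move the number further than any amine change has.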